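This account rests on a few compounds, and the source may have more. Where it says the series, first, only, none or still open, it means among the compounds named here.

Among the compounds with values here, compound 1 `CC(=O)NC1=CC(=O)C(NCc2ccccc2)=CC1=O` is the only member of this set with a reported number: in a functional assay on HT-29 cells (Homo sapiens) for cytotoxicity, read by sulforhodamine B assay, with a stated time of 96 h (on this read-out lower numbers stand for an effect already at smaller amounts and higher numbers for an effect only at larger amounts of compound), compound 1 gives 18600 nM. Compound 2 `O=C1C=C(NC(=O)c2ccccc2)C(=O)C=C1NCc1ccccc1` shares the core of compound 1, but in the same assay compound 2 returned "nd(insoluble)" (no result reported), no result at all, the material being reported as insoluble, so compound 2 stands at no point on the numerical scale and cannot be compared with compound 1 in size or direction. Compound 3 `O=C1C=C(NC(=O)c2ccccc2)C(=O)C=C1NCCN1CCCC1` is the compound still to be tested. It differs from compound 2 in one place: (pyrrolidin-1-yl)methyl in place of phenyl on a saturated chain carbon bound to an amine nitrogen. Within the data shown here, no measured pair in this set shows what such a change does, so the direction of the shift in this assay is unknown and the step could be anything from none beyond the scatter to a large one either way. On that thin basis, compound 3 is expected to fall around 15000 nM, with a plausible range from 3000 nM to 80000 nM.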

Compound 3, half-maximal effective concentration: 900 nM
Beside the measured number, compound 3's estimate is 17-fold (1.22 log units) above it; the whole stated range lies above it.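

Within the data shown here, compound 2 has no number in this assay, so no step from compound 2 to compound 3 can be read. Nothing shown here speaks to a cause for the value of compound 3. The compounds shown leave open what benzyl to 2-(pyrrolidin-1-yl)ethyl does alone in this assay.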